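Ring-nitrogen substituent change, compound 3 to compound 4

A few compounds are considered here, and "the series" means these few. Any claim that something is new, unique, unknown or untested is made for them only; others in the source may bear on it.

Measured so far in an assay on CHO cells for displacement of a labelled ligand from adenosine receptor A3 (Homo sapiens), read by scintillation counting, with a stated time of 45 min, tested at 1 uM, in the presence of a further agent that is not named here; a higher number here means more inhibition at the concentration tested (going by the name of the read-out), a lower number less inhibition:
compound 1 `CCCn1c(=O)[nH]c2nc(-c3ccc(S(=O)(=O)N4CCN(c5cccc(Br)c5)CC4)cc3)[nH]c2c1=O`: 27%
compound 2 `CCCn1c(=O)[nH]c2nc(-c3ccc(S(=O)(=O)N4CCN(c5ccccc5Br)CC4)cc3)[nH]c2c1=O`: 20%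
compound 3 `CCCn1c(=O)[nH]c2nc(-c3ccc(S(=O)(=O)N4CCN(c5ccc(F)cc5)CC4)cc3)[nH]c2c1=O`: 38%

Compound 3 stands highest of the three, with a number 11 percentage points higher from compound 1 to compound 3 (beyond the scatter) and a number 18 percentage points higher from compound 2 to compound 3 (beyond the scatter), while a number 7 percentage points lower from compound 1 to compound 2 (within the scatter). Compound 4 `CCCn1c(=O)[nH]c2nc(-c3ccc(S(=O)(=O)N4CCN(C(C)c5ccccc5)CC4)cc3)[nH]c2c1=O` differs from compound 3 by 1-phenylethyl in place of 4-fluorophenyl on an amine nitrogen in a ring. The three measured steps all swap one substituted phenyl for another on that ring nitrogen; none exchanges an aromatic group for 1-phenylethyl, so they bear only indirectly. Across the measured aryl variations the spread of this assay is modest. For compound 4 a step of a number 10 percentage points lower from compound 3 to compound 4 (within the scatter) is expected, downward, with wide uncertainty. Compound 4 is estimated at 28%, range 12% to 45%.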

Compound 4, a percentage reported as inhibition, at one concentration (the size of the read-out at that concentration, not a potency): 0%
Beside the measured number, compound 4's estimate is 28 percentage points above it; the whole stated range lies above it.
By their numbers in this assay, from the lowest: compound 4; then compounds 2 and 1 (each within the scatter of the next); then compound 3.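

In this assay, 1-phenylethyl on this ring nitrogen gives the largest step of the series: a number 38 percentage points lower from compound 3 to compound 4 (beyond the scatter). The loss also holds against both bromophenyl compounds, a number 27 percentage points lower from compound 1 to compound 4 (beyond the scatter) and a number 20 percentage points lower from compound 2 to compound 4 (beyond the scatter), so it does not depend on which of the three substituted phenyl groups leaves. All three steps lie beyond the scatter, so among the groups shown, the phenyl-bearing compounds 1, 2 and 3 keep measurable inhibition and compound 4 does not.

As far as these compounds go, whether a benzyl group on the same nitrogen would restore any of the number remains open. Nothing shown gives a reason for the drop.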